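The source may hold more compounds than are shown below. What is called first, only, known or untested is meant among the compounds shown, and "the series" means these compounds.

Of the compounds shown here, three built on one shared core have been measured in an assay for binding affinity to Corticotropin releasing factor receptor (Rattus norvegicus); a higher number here means a weaker inhibitor, a lower number a stronger inhibitor. Compound 2 `CCc1nc2c(-c3ccc(Cl)cc3Cl)ccnc2n1[C@H](C)C1CC1` gives 0.6 nM, the smallest of the three numbers, yet the other two lie within the usual scatter of it. Compound 1 `CCc1nc2c(-c3ccc(C(F)(F)F)cc3Cl)ccnc2n1C(CC)CCOC` gives 0.7 nM, and compound 3 `CCCC(C)n1c(CC)nc2c(-c3ccc(C(C)=O)cc3Cl)ccnc21` gives 1 nM, so no ranking among the three can be drawn. Compound 4 `CCc1nc2c(-c3ccc(Cl)cc3Cl)ccnc2n1C(CCOC)C1CC1` has not been measured in this assay. It differs from compound 2 in one place: 1-cyclopropyl-3-methoxypropyl in place of 1-cyclopropylethyl on an aromatic nitrogen. Among the measured compounds shown here, no measured pair isolates this change, so the step is expected to be small, in neither direction beyond the scatter. Compound 4 is estimated to give 0.8 nM, within a range from 0.3 nM to 2.5 nM. This expectation amounts to a 1.3-fold higher number from compound 2 to compound 4 (0.12 log units; within the scatter).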

Compound 4, inhibition constant: 1.5 nM
Beside the measured number, compound 4's estimate is 1.9-fold (0.27 log units) below it, within the range that was stated.
By their numbers in this assay, from the lowest: compounds 2, 1, 3 and 4 (each within the scatter of the next, the first and the last beyond it).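

In this assay, among the compounds shown here, this is the first isolated step at this position: swapping 1-cyclopropylethyl for 1-cyclopropyl-3-methoxypropyl on the aromatic nitrogen gives a 2.5-fold higher number from compound 2 to compound 4 (0.40 log units; beyond the scatter) and so costs a modest amount of binding. The larger group, with its hydrogen-bond acceptor, is accepted here, but the change also removes the defined stereocentre, so the chain and the stereochemistry are not separated. Nothing measured here explains the step. From the compounds shown here alone, whether a longer chain, or an amine or carboxylic acid in place of the methoxy group, would fit equally well remains open.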